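The compounds below may be only part of what the source reports. "The series", "measured", "known", "first", "only" and "open" are said of these compounds alone.

Of the compounds shown here, two built on a shared core have been tested in a functional assay on HepG2 cells (Homo sapiens) for antiproliferative activity, read by MTT assay, with a stated time of 72 h; a higher number here means a weaker inhibitor, a lower number a stronger inhibitor. Compound 1, `COc1ccc(-c2cn(C/C=C3\OC(=O)C(OCc4ccccc4)=C3OCc3ccccc3)nn2)cc1`, reaches only a limit of the assay in this assay, reported as > 100000 nM. Compound 2, `O=C1O[C@H]([C@@H](O)Cn2cc(-c3cc(F)cc(F)c3)nn2)C(OCc2ccccc2)=C1OCc1ccccc1`, gives a measured number in this assay, 11600 nM. Compound 2 therefore holds the only number shown, while the other entry is the limit of > 100000 nM in this assay, at which 1 of the 2 values shown sits. Compound 3, `O=C1O[C@H]([C@@H](O)Cn2cc(CCCCl)nn2)C(OCc2ccccc2)=C1OCc1ccccc1`, has not yet been measured in this assay.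

Compound 3 differs from compound 2 in one place: 3-chloropropyl in place of 3,5-difluorophenyl on an aromatic carbon. Going by the values given here, no step between two measured compounds is known here, so no measured change shows how such a swap moves the read-out. Compound 2 and compound 1 cannot be compared as a step either, since compound 1 gives only a limit.

In this assay the expected step is a 2.2-fold higher number from compound 2 to compound 3 (0.33 log units; beyond the scatter), a moderate weakening that may go beyond the usual scatter. Compound 3 is therefore estimated at 25000 nM in this assay. The range for compound 3 is expected to run from 8000 nM to 100000 nM, with a fair chance that only a limit is reported.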

Compound 3, half-maximal inhibitory concentration: 35000 nM
Compound 3: middle estimate off by 1.4-fold (0.15 log units), on the low side; the measured number falls inside the stated range.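

Going by these compounds alone, this is the first measured step at this position, an aromatic carbon of a five-membered aromatic ring with 3 nitrogen, and in this assay it reads a 3.0-fold higher number from compound 2 to compound 3 (0.48 log units; beyond the scatter). The change replaces a ring with an open chain, 3,5-difluorophenyl giving way to 3-chloropropyl, and the six-membered aromatic ring turns out not to be needed at this place for a measured number in this assay, although the inhibition is modestly weaker without it. Compound 1 remains the one entry that is a limit of the assay and not a number: the limit of > 100000 nM in this assay, at which 1 of the 3 values shown sits.

A single step changes several things at once, so the compounds shown cannot tell whether the loss comes from removing the aromatic ring, removing the two fluorines or adding the chlorine; a plain phenyl group and a propyl chain without chlorine would help to separate these. Also open, as far as these compounds go, is how a chain ending in an amine or a carboxylic acid in place of the chlorine would read in this assay.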